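Curcumin-derived enaminones: from sec-butyl to allyl on the nitrogen

The source may report more compounds than this note shows. Statements on the series, on what has been measured and on what is new or still open speak of the compounds shown alone.

Measured so far:
compound 1 `COc1cc(/C=C/C(=O)/C=C(/C=C/c2ccc(OC(C)=O)c(OC)c2)NC2CCCCC2)ccc1OC(C)=O` — 62%
compound 2 `CCCNC(=C\C(=O)/C=C/c1ccc(O)c(OC)c1)/C=C/c1ccc(O)c(OC)c1` — 88%
compound 3 `CCC(C)NC(=C\C(=O)/C=C/c1ccc(O)c(OC)c1)/C=C/c1ccc(O)c(OC)c1` — 66%

In a functional assay on Caco-2 cells (Homo sapiens), read by fluorescence, tested at 10 uM (a higher number here means a weaker effect of the compound at the concentration tested, a lower number a stronger effect), compound 3 gives 66%, the second highest of the three numbers; compound 1 lies within the scatter of it, while compound 2 sits beyond the scatter above it. Compound 4 `C=CCNC(=C\C(=O)/C=C/c1ccc(O)c(OC)c1)/C=C/c1ccc(O)c(OC)c1` differs from compound 3 by allyl in place of sec-butyl on an amine nitrogen. Within the data shown here, no measured step covers this exchange; the nearest is a number 22 percentage points lower from compound 2 to compound 3 (beyond the scatter), where the chain gained a methyl on the carbon bound to the nitrogen. Compound 4 carries a three-carbon chain again, closer in size to compound 2 than to compound 3, so a step back toward compound 2 of moderate size is expected: a number 12 percentage points higher from compound 3 to compound 4 (beyond the scatter). Compound 4 is thus estimated at 78%, within 60% to 95%.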

Compound 4, a percentage reported as activity, at one concentration (the size of the read-out at that concentration, not a potency): 76%
For compound 4 the middle estimate is 2 percentage points above the measured one, and the stated range covers the measured number.
By their numbers in this assay, from the lowest: compounds 1, 3 and 4 (each within the scatter of the next, the first and the last beyond it); then compound 2.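

Exchanging sec-butyl for allyl on the amine nitrogen gives a number 10 percentage points higher from compound 3 to compound 4 (within the scatter) in this assay, so this exchange does not separate the two groups. Vinyl in place of ethyl gives a number 12 percentage points lower from compound 2 to compound 4 (beyond the scatter) as a modest step, which shows that a change other than the added methyl of compound 3 can also set a chain on this nitrogen apart from the propyl chain of compound 2. Nothing available accounts for either step. The compounds shown leave open whether a benzyl group or a hydroxyethyl chain on this nitrogen would give a number like that of compound 2 or like those of compound 3 and compound 4.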